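Oxazolyl in place of methoxy on the arylpiperazine arm

The source may hold more compounds than are shown below. What is called first, only, known or untested is meant among the compounds shown, and "the series" means these compounds.

Values in a functional assay for antagonist activity at Alpha-1A adrenergic receptor (Oryctolagus cuniculus); a higher number here means weaker binding, a lower number tighter binding:

compound 1 `COc1ccccc1N1CCN(CCCNc2cncnc2C(=O)N(C)C)CC1`: 3.98 nM
compound 2 `CN(C)C(=O)c1cccnc1NCCCN1CCN(c2ccccc2OC(F)(F)F)CC1`: 3.16 nM
compound 3 `COc1cc(F)ccc1N1CCN(CCCNc2c(C(=O)N(C)C)cnc3c2c(C)nn3C)CC1`: 1.26 nM

Compound 3 stands lowest of the three numbers. Compound 2 is nearest to it and compound 1 furthest, and both gaps lie beyond the usual scatter. No pair among these three differs in one place only, so no measured single-point step is available in this assay.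

Compound 4 `Cc1nn(C)c2ncc(C(=O)N(C)C)c(NCCCN3CCN(c4ccc(F)cc4-c4ncco4)CC3)c12` shares the core of compound 3 and differs by 1,3-oxazol-2-yl in place of methoxy on an aromatic carbon; cut one bond further out, the same difference reads 4-fluoro-2-methoxyphenyl to 4-fluoro-2-(1,3-oxazol-2-yl)phenyl. Nothing in the measured set shows this exchange, so the direction of the step is open. The working expectation is a modest move toward a higher number, of a size not clearly beyond the scatter, with the estimated step of a 2.0-fold higher number from compound 3 to compound 4 (0.30 log units; within the scatter). Compound 4 is accordingly expected near 2.5 nM, within a range from 0.8 nM to 8 nM.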

Compound 4, dissociation constant: 0.126 nM
Compound 4: middle estimate off by 20-fold (1.30 log units), on the high side, outside the stated range (below it).
By their numbers in this assay, from the lowest: compound 4; then compound 3; then compounds 2 and 1 (each within the scatter of the next).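

In this assay, 1,3-oxazol-2-yl in place of methoxy on this aromatic carbon gives a 10-fold lower number from compound 3 to compound 4 (1.00 log units; beyond the scatter), the first single-point step available in the series, and it lies beyond the scatter. The position, ortho to a large group and meta to a fluoro group, therefore accepts a five-membered aromatic ring with 2 hetero atoms, and the number falls even though the entering group has 5 heavy atoms against 2 for methoxy. The information at hand offers no account of why this exchange lowers the number.

Whether a similar step would appear on the core of compound 1 or of compound 2 remains open, since this exchange is shown on one core only. Also open, as far as these compounds go, is whether the lower number depends on the oxazole itself or would persist with a thiazole, a pyrazole or a simple nitrile at this carbon.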